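The source may report more compounds than this note shows. Statements on the series, on what has been measured and on what is new or still open speak of the compounds shown alone.

Values in an ADME assay on microsomes from liver (Mus musculus) for metabolic stability, read by LC-MS, with a stated time of 30 min, tested at 1 uM; on this read-out higher numbers stand for a more stable compound and lower numbers for a less stable compound:
- compound 1 `O=C(NCc1ccc(S(=O)(=O)N2CCCCC2)cc1)c1cnc2nccn2c1`: 0.28%
- compound 2 `O=C(NCc1ccc(S(=O)(=O)c2cc(F)cc(F)c2)cc1)c1cnc2nccn2c1`: 71%
- compound 3 `O=C(NCc1ccc(S(=O)(=O)c2cccc(C(F)(F)F)c2)cc1)c1cc2ccncc2o1`: 64%

In this assay, compound 3 at 64% lies within the scatter of compound 2 and far beyond the scatter above compound 1.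

Compound 4 `O=C(NCc1ccc(S(=O)(=O)c2cccc(C(F)(F)F)c2)cc1)c1cnc2nccn2c1` follows from compound 3 by one change: a group of 9 heavy atoms (6 carbon, 3 nitrogen; one five-membered aromatic ring with 2 hetero atoms, one six-membered aromatic ring with 2 hetero atoms) in place of a group of 9 heavy atoms (7 carbon, 1 nitrogen, 1 oxygen; one five-membered aromatic ring with 1 hetero atom, one six-membered aromatic ring with 1 hetero atom), on a carbonyl carbon. For the measured compounds named here, no measured step covers a change on this carbonyl carbon. Going by the values given here, the only measured step, a number 70.7 percentage points higher from compound 1 to compound 2 (beyond the scatter), lies at the sulfonyl sulfur, so it bears on this change only indirectly. It shows that the group entering here occurs with both a very low and a high number. Compound 4 keeps the sulfonyl substituent of compound 3, and compound 2, with the entering group and an aromatic ring on the sulfonyl sulfur, stands at 71%. No step beyond the scatter is therefore expected, though the uncertainty is wide. The expected step is a number 2 percentage points higher from compound 3 to compound 4 (within the scatter). The estimated value for compound 4 is 66%, with an expected range of 42% to 84%.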

Compound 4, percent of the compound remaining: 27%
Estimate against measurement, compound 4: 39 percentage points above; the whole stated range lies above it.
By their numbers in this assay, from the lowest: compound 1; then compound 4; then compounds 3 and 2 (each within the scatter of the next).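

In this assay, the carbonyl carbon turns out to be a sensitive place: the exchange of the two bicyclic groups there gives a number 37 percentage points lower from compound 3 to compound 4 (beyond the scatter), so with 3-(trifluoromethyl)phenyl on the sulfonyl sulfur the two groups are not interchangeable. With the entering group held constant, the aromatic substituent on the sulfonyl sulfur also matters, giving a number 44 percentage points lower from compound 2 to compound 4 (beyond the scatter), while the replacement of piperidin-1-yl gives only a number 26.7 percentage points higher from compound 1 to compound 4 (beyond the scatter). No measurement at hand accounts for either effect.

Going by these compounds, it remains open whether the carbonyl exchange gives a similar step with 3,5-difluorophenyl on the sulfonyl sulfur. Also open, on these data alone, is how a morpholine or a cyclohexyl group on the sulfonyl sulfur would fall on this scale.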